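Cytotoxicity of a benzimidazole amide series on Vero cells

A few compounds are considered here, and "the series" means these few. Any claim that something is new, unique, unknown or untested is made for them only; others in the source may bear on it.

Compound 1 `COc1ccc(C(=O)Nc2cc3nc(C4CCCCC4)[nH]c3cc2N(C)C)cc1` in an ADME assay on Vero cells (Chlorocebus sabaeus) for cytotoxicity, read by resazurin assay, with a stated time of 3 days (on this read-out lower numbers stand for stronger inhibition and higher numbers for weaker inhibition), gives > 100 ug/mL, which is a limit of the assay. Compound 2 `CN(C)c1cc2[nH]c(C3CCCCC3)nc2cc1NC(=O)c1cccc(Br)c1` likewise gives > 100 ug/mL, again a limit. The step that the two limits leave unreadable from compound 1 to compound 2 is therefore unreadable, and compound 2 stands at the limit shared by both values (the limit of > 100 ug/mL in this assay, at which 2 of the 2 values shown sit). Compound 3 `CCCCNC(=O)Nc1cc2nc(C3CCCCC3)[nH]c2cc1N(C)C` differs by butylamino in place of 3-bromophenyl on a carbonyl carbon. For the measured compounds named here, no measured step bears readably on this change, so no shift beyond the scatter is expected, and the estimated step that the limit leaves unreadable from compound 2 to compound 3 is small. Compound 3 is expected to give about 150 ug/mL, within 60 ug/mL to 400 ug/mL.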

Compound 3, half-maximal inhibitory concentration: > 100 ug/mL
Compound 3 gave a limit, no number (the forecaster's own chance of this, stated with the estimate: 85%); the middle value does not contradict the limit.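

No new step can be read among compound 1, compound 2 and compound 3 in this assay, and all three share a single limit: the limit of > 100 ug/mL in this assay, at which 3 of the 3 values shown sit.

The compounds shown leave open whether 4-methoxyphenyl, 3-bromophenyl and butylamino on the carbonyl carbon differ at all in cytotoxicity.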